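A Ring-Nitrogen Group That Weakens Platelet Inhibition

The source may report more compounds than this note shows. Statements on the series, on what has been measured and on what is new or still open speak of the compounds shown alone.

Of the compounds shown here, three have been measured in a functional assay on a cell-free system (Platelet, plasma, Homo sapiens) for inhibition; a lower number here means a stronger inhibitor, a higher number a weaker inhibitor. Compound 1 `O=C(Nc1cccc(OCc2ccc(-c3ccccc3)cc2)c1)C1CCCNC1` gives 153000 nM. Compound 2 `N=C(N)N1CCCC(C(=O)Nc2cccc(OCc3ccc(-c4ccccc4)cc3)c2)C1` differs from compound 1 only at the ring nitrogen; the difference is a group of 3 heavy atoms (1 carbon, 2 nitrogen; no ring) in place of a hydrogen atom, on an amine nitrogen in a ring and in this assay compound 2 gives 1000000 nM, so the step of a 6.5-fold higher number from compound 1 to compound 2 (0.82 log units; beyond the scatter) goes toward weaker inhibition. Compound 3 `O=C(Nc1cccc(OCc2ccc(F)cc2)c1)C1CCNCC1` has a different core, and how its core differs from the core of compound 1 is not broken down here. In this assay compound 3 gives 68000 nM, the lowest of the three numbers.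

Compound 4 `N=C(N)N1CCC(C(=O)Nc2cccc(OCc3ccc(F)cc3)c2)CC1` is not yet measured. It differs from compound 3 by a group of 3 heavy atoms (1 carbon, 2 nitrogen; no ring) in place of a hydrogen atom, on an amine nitrogen in a ring. Going by the values given here, this is the same kind of change as the one from compound 1 to compound 2, though not the same: in compound 2 the nitrogen sits two ring bonds from the ring atom that bears a large group, in compound 4 three ring bonds. If the change acts alike on the core of compound 3, a step of a 5.9-fold higher number from compound 3 to compound 4 (0.77 log units; beyond the scatter) is expected, resting on a 6.5-fold higher number from compound 1 to compound 2 (0.82 log units; beyond the scatter). Compound 4 is therefore estimated at 400000 nM, between 100000 nM and 1500000 nM.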

Compound 4, half-maximal inhibitory concentration: 768000 nM
Beside the measured number, compound 4's estimate is 1.9-fold (0.28 log units) below it; measured number inside the range.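

In this assay, putting the group of 3 heavy atoms on the ring nitrogen gives an 11-fold higher number from compound 3 to compound 4 (1.05 log units; beyond the scatter), so on this second core the change again goes toward weaker inhibition. The two steps point the same way and cannot be told apart in size: the same change on two cores in this assay, a 6.5-fold higher number (0.82 log units; beyond the scatter) from compound 1 to compound 2 and an 11-fold higher number (1.05 log units; beyond the scatter) from compound 3 to compound 4, 1.7-fold (0.24 log units) apart, within the scatter of two such steps Within this series, the change therefore carried over from the core of compound 1 to the core of compound 3, but two cores cannot show that it would do so on any other core, and the data give no reason for the weakening or separate the position of the ring nitrogen from the other differences between the cores.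

The compounds shown leave open whether a smaller group on the same ring nitrogen, such as a methyl or an acetyl group, would also weaken inhibition. They also leave open whether the step would keep its size with the nitrogen three ring bonds from the large group on the core of compound 1.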